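The source may report more compounds than this note shows. Statements on the series, on what has been measured and on what is new or still open speak of the compounds shown alone.

In a functional assay on HOS-TE85 cells (Homo sapiens) for inhibition, read by CCK-8 assay, with a stated time of 72 h (on this read-out higher numbers stand for weaker inhibition and lower numbers for stronger inhibition), three compounds sharing one core have been measured. Compound 1 `CCN(CC)c1ccc(N2C(=O)CSC2c2cccc(C(=O)NCCCCc3ccccc3)c2)cc1` gives only a limit of the assay, > 1000 nM and no number. Compound 2 `COc1ccc(F)cc1N1C(=O)CSC1c1cccc(C(=O)NCCCCc2ccccc2)c1` gives 8.8 nM there. Compound 3 `C#Cc1cccc(N2C(=O)CSC2c2cccc(C(=O)NCCCCc3ccccc3)c2)c1` gives 149 nM there, the higher of the two real numbers. Compound 4 `O=C(NCCCCc1ccccc1)c1cccc(C2SCC(=O)N2c2ccccc2F)c1` differs from compound 3 by one swap (2-fluorophenyl in place of 3-ethynylphenyl on an amide-type nitrogen in a ring) on the amide-type nitrogen in the ring. Swaps at this place have already produced large steps (an at least 110-fold lower number from compound 1 to compound 2 (2.05 log units; beyond the scatter)) and (a 17-fold higher number from compound 2 to compound 3 (1.23 log units; beyond the scatter)), and an at least modest one (an at least 6.7-fold lower number from compound 1 to compound 3 (0.82 log units; beyond the scatter)). Compound 2 also carries a fluorine on this ring, so part of that last large step (a 17-fold higher number from compound 2 to compound 3 (1.23 log units; beyond the scatter)) may be expected to return. The expected step (a 3.0-fold lower number from compound 3 to compound 4 (0.47 log units; beyond the scatter)) is moderate, toward stronger inhibition. Compound 4 is estimated at 50 nM with an expected range from 10 nM to 300 nM overall.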

Compound 4, half-maximal inhibitory concentration: 34.1 nM
Beside the measured number, compound 4's estimate is 1.5-fold (0.17 log units) above it, within the range that was stated.
By their numbers in this assay, from the lowest: compound 2; then compound 4; then compound 3. At a limit, above all of these: compound 1.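

A single fluorine is enough to give a substantial gain over the ethynyl-bearing ring, with 2-fluorophenyl giving a 4.4-fold lower number from compound 3 to compound 4 (0.64 log units; beyond the scatter). It does not match 5-fluoro-2-methoxyphenyl, however, as shown by a 3.9-fold higher number from compound 2 to compound 4 (0.59 log units; beyond the scatter), so fluorine alone does not account for the full activity of compound 2. The comparison with compound 1 gives only a bound, an at least 29-fold lower number from compound 1 to compound 4 (1.46 log units; beyond the scatter), since compound 1 stands at a limit: the limit of > 1000 nM in this assay, at which 1 of the 4 values shown sits.

Still open, on these data alone, is how plain phenyl or 2-methoxyphenyl would compare on this nitrogen. As far as these compounds go, the effect of a chlorine in place of the fluorine also remains unknown.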